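Methoxyphenyl variants on a shared amide core

The source may report more compounds than this note shows. Statements on the series, on what has been measured and on what is new or still open speak of the compounds shown alone.

Measured compounds and their solubility:
compound 1, `CNC(=O)c1cc(C(=O)NC2CC2)cn(Cc2cccc(OC)c2)c1=O`: 582 ug/mL
compound 2, `CNC(=O)c1cc(C(=O)NC2CCC2)cn(Cc2ccccn2)c1=O`: 920 ug/mL
compound 3, `CNC(=O)c1cc(C(=O)NC2CCC2)cn(Cc2ccccc2)c1=O`: 24 ug/mL

In a physicochemical assay for solubility, read by HPLC, in simulated intestinal fluid, with a stated time of 16 h, tested at 125 ug/mL (on this read-out lower numbers stand for lower solubility and higher numbers for higher solubility), compound 1 stands second highest of the three numbers. Its nearest neighbour is compound 2, whose number is within the scatter of it, and its furthest is compound 3, which lies well below it, beyond the scatter.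

Compound 4, `CNC(=O)c1cc(C(=O)NC2CC2)cn(Cc2ccc(OC)cc2)c1=O`, has the same atoms as compound 1, joined differently: 4-methoxyphenyl in place of 3-methoxyphenyl on a saturated chain carbon bound to an aromatic nitrogen. For the measured compounds named here, the only single-place step measured so far is a 38-fold lower number from compound 2 to compound 3 (1.58 log units; beyond the scatter), which sits at the same place, a saturated chain carbon bound to an aromatic nitrogen, but exchanges one aromatic group for another of a different kind. Going by the values given here, no measured step exchanges a 3-methoxyphenyl for a 4-methoxyphenyl, so that large step cannot be carried over directly. The move from compound 1 to compound 4 is therefore expected to stay within the scatter, with a small drift downward at most, a 1.3-fold lower number from compound 1 to compound 4 (0.11 log units; within the scatter). Compound 4 is estimated at 450 ug/mL, expected to fall between 150 ug/mL and 950 ug/mL.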

Compound 4, solubility: 263 ug/mL
Estimate against measurement, compound 4: 1.7-fold (0.23 log units) above, within the range that was stated.
By their numbers in this assay, from the lowest: compound 3; then compound 4; then compounds 1 and 2 (each within the scatter of the next).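

In this assay, 4-methoxyphenyl in place of 3-methoxyphenyl on a saturated chain carbon bound to an aromatic nitrogen gives a 2.2-fold lower number from compound 1 to compound 4 (0.34 log units; beyond the scatter) and so lies just beyond the usual scatter. Until now this position had shown a change only with a different aromatic group, in a 38-fold lower number from compound 2 to compound 3 (1.58 log units; beyond the scatter), whereas here the groups that leave and enter have the same heavy atoms, the same ring and the same counts of donors and acceptors, and the number still moves. Nothing available explains this step.

On these data alone, it remains open how an amine or a carboxylic acid on the phenyl ring would read in place of the methoxy group. For the compounds shown here, it is also open whether this step keeps its size when the amide on the shared core carries a group other than the one in compound 1 and compound 4.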